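Acyl variation on the piperidine nitrogen and Caco-2 permeability

The source may report more compounds than this note shows. Statements on the series, on what has been measured and on what is new or still open speak of the compounds shown alone.

Compound 1 `CCC(=O)N1CCC(CN(C2Cc3cc(C#N)ccc3N(Cc3cncn3C)C2)S(=O)(=O)c2ccccn2)CC1` gives 0.5 10^-6 cm/s in an ADME assay on Caco-2 cells (Homo sapiens) for permeability, in the apical to basolateral direction (a higher number here means that the compound crosses the layer faster, a lower number that the compound crosses the layer more slowly), level with compound 2 `Cn1cncc1CN1CC(N(CC2CCN(C(=O)CC(C)(C)C)CC2)S(=O)(=O)c2ccccn2)Cc2cc(C#N)ccc21` at 0.5 10^-6 cm/s and compound 3 `CC(=O)N1CCC(CN(C2Cc3cc(C#N)ccc3N(Cc3cncn3C)C2)S(=O)(=O)c2ccccn2)CC1` at 0.5 10^-6 cm/s. The steps of no change at the digits printed from compound 1 to compound 2 (within the scatter) and no change at the digits printed from compound 1 to compound 3 (within the scatter) both change the group on the saturated chain carbon bound to the carbonyl carbon, and no change at the digits printed from compound 2 to compound 3 (within the scatter) does the same; none moves the read-out. Compound 4 `Cn1cncc1CN1CC(N(CC2CCN(C(=O)Nc3ccc(Br)cc3)CC2)S(=O)(=O)c2ccccn2)Cc2cc(C#N)ccc21` differs from compound 1 by (4-bromophenyl)amino in place of ethyl on a carbonyl carbon. The three measured steps all alter this same carbonyl substituent, so the same flat outcome is expected, with a wider range because the entering group is larger and carries one hydrogen-bond donor. The expected step is no change at the digits printed from compound 1 to compound 4 (within the scatter). For compound 4 the estimate is 0.5 10^-6 cm/s, between 0.2 10^-6 cm/s and 1.2 10^-6 cm/s.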

Compound 4, apparent permeability: 0.6 10^-6 cm/s
For compound 4 the middle estimate is 1.2-fold (0.08 log units) below the measured one; the measured number falls inside the stated range.
By their numbers in this assay, from the lowest: compounds 1, 2, 3 and 4 (each within the scatter of the next).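

Among these compounds, with (4-bromophenyl)amino on the carbonyl carbon, the entering group brings an aromatic ring and a hydrogen-bond donor to this position for the first time, yet the read-out in this assay stays flat (a 1.2-fold higher number from compound 1 to compound 4 (0.08 log units; within the scatter)) (a 1.2-fold higher number from compound 3 to compound 4 (0.08 log units; within the scatter)) (a 1.2-fold higher number from compound 2 to compound 4 (0.08 log units; within the scatter)). Across these four compounds, the substituent on this carbonyl carbon therefore ranges from methyl to (4-bromophenyl)amino without a step beyond the scatter. Nothing available gives a reason for this flat outcome.

Open, from the compounds shown here alone, is whether an aliphatic amine or a carboxylic acid at this position would shift the read-out. Also open, going by these compounds, is whether the bromine contributes anything, which the unsubstituted phenylamino group would test.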